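The source may report more compounds than this note shows. Statements on the series, on what has been measured and on what is new or still open speak of the compounds shown alone.

Compound 1 `Fc1ccc(C2(c3ccc(F)cc3)CNC(c3cccc(Br)c3)=N2)cc1`: 4.8 nM
Compound 2 `OCc1cccc(C2=NC(c3ccc(F)cc3)(c3ccc(F)cc3)CN2)c1`: 59 nM

Of the compounds shown here, two have been tested in an assay on LM cells for displacement of a labelled ligand from Neuropeptide Y receptor type 5 (Homo sapiens); a higher number here means a weaker inhibitor, a lower number a stronger inhibitor. Compound 1 `Fc1ccc(C2(c3ccc(F)cc3)CNC(c3cccc(Br)c3)=N2)cc1` gives 4.8 nM there, while compound 2 `OCc1cccc(C2=NC(c3ccc(F)cc3)(c3ccc(F)cc3)CN2)c1` gives 59 nM. Among the measured compounds shown here, compound 2 thus stands at the higher of the two numbers, and its only measured neighbour is compound 1: a 12-fold higher number from compound 1 to compound 2 (1.09 log units; beyond the scatter), a change described as large.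

Compound 3 `Fc1ccc(C2(c3ccc(F)cc3)CNC(c3ccncc3)=N2)cc1` has not yet been measured. It differs from compound 2 in one place: pyridin-4-yl in place of 3-(hydroxymethyl)phenyl on a carbon with a double bond to nitrogen. For the measured compounds named here, no measured step covers this exact exchange. Going by the values given here, the one known step, a 12-fold higher number from compound 1 to compound 2 (1.09 log units; beyond the scatter), concerns a different group at the same carbon and shows only that changes at this position can move the number considerably. The direction for compound 3 is uncertain, so the expectation is a modest move back toward lower numbers with a wide range. Compound 3 is expected to give about 30 nM in this assay, between 8 nM and 120 nM. The estimated step is a 2.0-fold lower number from compound 2 to compound 3 (0.29 log units; within the scatter).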

Compound 3, half-maximal inhibitory concentration: 160 nM
Compound 3: middle estimate off by 5.3-fold (0.73 log units), on the low side, outside the stated range (above it).
By their numbers in this assay, from the lowest: compound 1; then compound 2; then compound 3.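

Exchanging 3-(hydroxymethyl)phenyl for pyridin-4-yl on this ring carbon in this assay gives a 2.7-fold higher number from compound 2 to compound 3 (0.43 log units; beyond the scatter), and the distance from the 3-bromophenyl group is larger still, at a 33-fold higher number from compound 1 to compound 3 (1.52 log units; beyond the scatter). This position therefore ranks all three groups clearly, with 3-bromophenyl giving the lowest number and pyridin-4-yl the highest, so placing a nitrogen in the six-membered ring and dropping the side group does not bring back the strength lost with the bromo group. Nothing available explains why the number rises with this change.

Compound 3 changes the ring atom and removes the side group together, so the compounds shown cannot tell how much each change contributes. A plain phenyl group or a pyridin-3-yl group at this carbon would help to separate the two.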